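Swapping Furan for Thiophene on a Compound with a Low Inhibition Number

The source may hold more compounds than are shown below. What is called first, only, known or untested is meant among the compounds shown, and "the series" means these compounds.

Of the compounds shown here, three sharing one core have been tested in a functional assay on PANC-1 cells (Homo sapiens) for inhibition, read by MTT assay, with a stated time of 24 h, tested at 10 uM; on this read-out lower numbers stand for less inhibition and higher numbers for more inhibition at the one concentration tested (going by the name of the read-out). Compound 1 `CCOc1cc(=O)n(CCCO)c2c1CC(CC=C(C)C)C(C)(C)C2` gives 16.6%. Compound 2 `CC(C)=CCC1Cc2c(OCc3ccccc3)cc(=O)n(CCCO)c2CC1(C)C` gives 11.1%. Compound 3 `CC(C)=CCC1Cc2c(OCCCNC(=O)c3ccco3)cc(=O)n(CCCO)c2CC1(C)C` gives 4.3%, the lowest of the three numbers, though its gap to compound 2 lies within the scatter and only its gap to compound 1 lies beyond it. The step of a number 12.3 percentage points lower from compound 1 to compound 3 (beyond the scatter) is modest, while a number 5.5 percentage points lower from compound 1 to compound 2 (within the scatter) and a number 6.8 percentage points lower from compound 2 to compound 3 (within the scatter) stay within the scatter.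

Compound 4 `CC(C)=CCC1Cc2c(OCCCNC(=O)c3cccs3)cc(=O)n(CCCO)c2CC1(C)C` differs from compound 3 in one place: thiophen-2-yl in place of furan-2-yl on a carbonyl carbon. The chain, the amide and the rest of the core are unchanged. For the measured compounds named here, none of the measured steps exchanges one five-membered aromatic ring for another, so no step bears directly on this change; the measured steps only show that altering the group on the oxygen of the aromatic ring has moved this read-out by small amounts, once modestly.

Compound 4 is therefore expected to show a step of about a number 1.7 percentage points higher from compound 3 to compound 4 (within the scatter), that is, no change beyond the scatter. In this assay compound 4 is estimated at 6%, with a likely range from -5% to 18%.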

Compound 4, a percentage reported as inhibition, at one concentration (the size of the read-out at that concentration, not a potency): 5.6%
Compound 4: middle estimate off by 0.4 percentage points, on the high side; the range from low to high includes it.
By their numbers in this assay, from the lowest: compounds 3, 4, 2 and 1 (each within the scatter of the next, the first and the last beyond it).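

In this assay, for the compounds shown here, this is the first direct test of the position, and it gives a number 1.3 percentage points higher from compound 3 to compound 4 (within the scatter): on a carbonyl carbon bound to an amide-type nitrogen, thiophen-2-yl and furan-2-yl, two five-membered aromatic rings of the same size that differ in one ring atom (sulfur for oxygen), cannot be told apart on this read-out. The thiophene-bearing compound also relates to the other two compounds much as the furan-bearing one does, with a number 5.5 percentage points lower from compound 2 to compound 4 (within the scatter) and a number 11 percentage points lower from compound 1 to compound 4 (beyond the scatter), so the modest gap to compound 1 does not rest on the furan-2-yl ring alone. Nothing measured on these compounds offers a reason why the two rings read alike.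

From the compounds shown here alone, all four numbers are small and each comes from one concentration, so it stays open whether any group on this carbonyl carbon could give clearly more inhibition. A six-membered ring such as pyridin-2-yl, a plain methyl, a carboxylic acid in place of the amide, or a longer chain carrying the same amide could each answer part of that question.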